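Swapping the Cap on Compound 4's Amine Nitrogen

The source may hold more compounds than are shown below. What is called first, only, known or untested is meant among the compounds shown, and "the series" means these compounds.

Of the compounds shown here, three have been measured in a functional assay on MCF7 cells (Homo sapiens) for cytotoxicity, read by MTT assay, with a stated time of 48 h; a lower number here means a stronger inhibitor, a higher number a weaker inhibitor. Compound 1 `CCCCCCCCCCCCCCNC(=O)[C@@H](N)[C@@H](C)O` gives 10700 nM. Compound 2 `CCCCCCCCCCCCCCNC(=O)[C@@H](NC(=O)c1ccccc1)[C@@H](C)O` gives 24800 nM, and compound 3 `C/C=C/C=C/C(=O)N[C@H](C(=O)NCCCCCCCCCCCCCC)[C@@H](C)O` gives 27800 nM. Compound 3 holds the highest number of the three: a 1.1-fold higher number from compound 2 to compound 3 (0.05 log units; within the scatter), while a 2.6-fold higher number from compound 1 to compound 3 (0.41 log units; beyond the scatter).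

Compound 4 `CCCCCCCCCCCCCCNC(=O)[C@@H](NS(=O)(=O)c1ccc(C)cc1)[C@@H](C)O` differs from compound 3 in one place: (4-methylphenyl)sulfonyl in place of (penta-1,3-dien-1-yl)carbonyl on an amine nitrogen. Among the compounds with values here, two measured steps bear on this change. Placing a cap on the amine nitrogen raised the number modestly in both cases, a 2.3-fold higher number from compound 1 to compound 2 (0.37 log units; beyond the scatter) and a 2.6-fold higher number from compound 1 to compound 3 (0.41 log units; beyond the scatter), and exchanging one cap for another made no difference beyond the scatter, a 1.1-fold higher number from compound 2 to compound 3 (0.05 log units; within the scatter). On that basis the new cap is expected to behave much like the two already seen, so in this assay no step beyond the scatter is expected, a 1.1-fold lower number from compound 3 to compound 4 (0.03 log units; within the scatter). Compound 4 is therefore estimated at 26000 nM, with a range from 10000 nM to 65000 nM.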

Compound 4, half-maximal inhibitory concentration: 12900 nM
Beside the measured number, compound 4's estimate is 2.0-fold (0.30 log units) above it; low and high end bracket the measured number.
By their numbers in this assay, from the lowest: compounds 1, 4, 2 and 3 (each within the scatter of the next, the first and the last beyond it).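

In this assay, replacing one cap on the amine nitrogen with another now makes a difference beyond the scatter, a 2.2-fold lower number from compound 3 to compound 4 (0.33 log units; beyond the scatter), which the exchange of benzoyl for (penta-1,3-dien-1-yl)carbonyl did not. The (4-methylphenyl)sulfonyl cap stays within the scatter of the free amine, a 1.2-fold higher number from compound 1 to compound 4 (0.08 log units; within the scatter), and also of the benzoyl cap, a 1.9-fold lower number from compound 2 to compound 4 (0.28 log units; within the scatter), so the rise beyond the scatter seen with the two carbonyl-linked caps is not shared by this sulfonyl cap. Nothing available explains why the caps differ in this way.

From the compounds shown here alone, whether a methanesulfonyl or a plain benzenesulfonyl cap would track compound 4 remains open, as does how a 4-methylbenzoyl cap would compare with it. Also open, going by these compounds, is whether the same step would appear with a shorter chain in place of the long chain of the shared core.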